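Thiazolyl sulfone in place of methoxyphenyl sulfone

The source may report more compounds than this note shows. Statements on the series, on what has been measured and on what is new or still open speak of the compounds shown alone.

Compound 1 `COc1cccc(S(=O)(=O)c2ccc(NC(=O)C(C)(O)C(F)(F)F)cc2)c1` holds the higher of the two numbers in a functional assay (Cavia porcellus) with sulfonylurea receptors; K-ATP channels (Homo sapiens) as the target; a lower number here means a stronger inhibitor, a higher number a weaker inhibitor; in this assay compound 1 gives 16000 nM. Compound 3 `CC(O)(C(=O)Nc1ccc(C(=O)c2ccccc2)cc1C#N)C(F)(F)F` gives 3800 nM in this assay, a lower number that lies beyond the usual scatter. Compound 2 `CO/N=C(/c1ccccc1)c1ccc(NC(=O)C(C)(O)C(F)(F)F)cc1` reaches only a limit of this assay, reported as > 30000 nM; this is the limit of > 30000 nM in this assay, at which 1 of the 3 values shown sits. Compound 4 `CC(O)(C(=O)Nc1ccc(S(=O)(=O)c2nccs2)cc1)C(F)(F)F` has not yet been measured; it differs from compound 1 by 1,3-thiazol-2-yl in place of 3-methoxyphenyl on a sulfonyl sulfur. Within the data shown here, no measured pair carries this change, so its size is unknown. The step from compound 1 to compound 4 is expected to be a 1.6-fold lower number from compound 1 to compound 4 (0.20 log units; within the scatter), a modest move toward a lower number that may not exceed the scatter. Compound 4 is estimated at 10000 nM, with a range from 3000 nM to 30000 nM.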

Compound 4, half-maximal inhibitory concentration: 1400 nM
Compound 4: middle estimate off by 7.1-fold (0.85 log units), on the high side; measured number below the stated range.
By their numbers in this assay, from the lowest: compound 4; then compound 3; then compound 1. At a limit, above all of these: compound 2.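

In this assay, the group on the sulfonyl sulfur strongly affects the read-out: swapping 3-methoxyphenyl for 1,3-thiazol-2-yl gives an 11-fold lower number from compound 1 to compound 4 (1.06 log units; beyond the scatter). This position therefore accepts a five-membered aromatic ring with 2 hetero atoms and fewer heavy atoms, and the inhibitor gets stronger. No measurement shown bears on why the step is this large. A single pair cannot separate the effect of ring size from that of the hetero atoms. As far as these compounds go, whether a 1,3-oxazol-2-yl or pyridin-2-yl group on the sulfonyl sulfur would keep the lower number remains open.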